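Swapping the aryl group in a series stuck at a limit

The source may hold more compounds than are shown below. What is called first, only, known or untested is meant among the compounds shown, and "the series" means these compounds.

Half-life values in an ADME assay on microsomes from liver (Canis lupus familiaris) for metabolic stability (a higher number here means that the compound lasts longer, a lower number that the compound disappears faster), stand as follows
- compound 1 `Nc1nc(NCCNc2ncc(-c3ncc[nH]3)c(-c3ccc(F)cc3Br)n2)ccc1[N+](=O)[O-]` shows > 0.5 h as a limit
- compound 2 `Nc1nc(NCCNc2ncc(-c3ncc[nH]3)c(-c3cc(F)c(Cl)cc3Cl)n2)ccc1[N+](=O)[O-]` shows > 0.5 h as a limit
- compound 3 `Nc1nc(NCCNc2ncc(-c3ncc[nH]3)c(-c3ccc(Br)cc3Cl)n2)ccc1[N+](=O)[O-]` shows > 0.5 h as a limit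

Compound 3 stands at > 0.5 h as a limit and not a number. Across the series the evidence is the limit of > 0.5 h in this assay, at which 3 of the 3 values shown sit, and nothing finer. Compound 4 `Cc1cc(Cl)ccc1-c1nc(NCCNc2ccc([N+](=O)[O-])c(N)n2)ncc1-c1ncc[nH]1` differs from compound 3 by 4-chloro-2-methylphenyl in place of 4-bromo-2-chlorophenyl on an aromatic carbon on an aromatic carbon ortho to a 1H-imidazol-2-yl group. Three aryl exchanges bear on this, namely a step that the two limits leave unreadable from compound 1 to compound 3 and a step that the two limits leave unreadable from compound 2 to compound 3 and also a step that the two limits leave unreadable from compound 1 to compound 2 with no size to carry over. No step beyond the scatter is therefore expected in this assay and no direction can be given. The step expected is a number no higher from compound 3 to compound 4 (the limit leaves the size open) by estimate. Compound 4 is estimated at 0.5 h with an expected range from 0.3 h to 1 h for the measurement.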

Compound 4, half-life: > 0.5 h
Compound 4: a limit, no number; the forecaster's own chance of this, stated with the estimate: 70%; the middle value lies on the limit itself.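

In this assay compound 4 gives > 0.5 h, a limit and not a number. The steps to compound 4 from compound 1, compound 2 and compound 3 cannot be read. The compounds shown leave open the actual half-life of each and any order among them: the limit of > 0.5 h in this assay, at which 4 of the 4 values shown sit.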